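Compound 4 and the swap to 5-carboxypyrazin-2-yl

A few compounds are considered here, and "the series" means these few. Any claim that something is new, unique, unknown or untested is made for them only; others in the source may bear on it.

Compound 1 `O=C(O)c1cccc(NC(=O)[C@H](CC2CCCC2)n2cnc(C(F)(F)F)c2)n1` gives 0.7 10^-6 cm/s in an ADME assay on MDCKII-LE cells (Canis lupus familiaris) for permeability; a lower number here means that the compound crosses the layer more slowly, a higher number that the compound crosses the layer faster. Two relatives sharing its core have also been measured. Compound 2 `O=C(O)Cc1ccc(NC(=O)[C@H](CC2CCCC2)n2cnc(C(F)(F)F)c2)nc1` gives 0.4 10^-6 cm/s, and compound 3 `O=C(Nc1ccc(-c2nnn[nH]2)cn1)[C@H](CC1CCCC1)n1cnc(C(F)(F)F)c1` gives 0.6 10^-6 cm/s. These three numbers all lie within the usual scatter of one another, so compound 1 stands level with both relatives and cannot be ranked against them.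

Compound 4 `O=C(O)c1cnc(NC(=O)[C@H](CC2CCCC2)n2cnc(C(F)(F)F)c2)cn1` has not yet been measured. It differs from compound 1 in one place, on an amide-type nitrogen, where 5-carboxypyrazin-2-yl stands in place of 6-carboxypyridin-2-yl (5-carboxypyrazin-2-yl in place of 6-carboxypyridin-2-yl on an amide-type nitrogen).

Within the data shown here, no measured step shows this exact exchange, so the evidence is indirect. Among the measured compounds shown here, the only single-place step available puts 1H-tetrazol-5-yl in place of carboxymethyl on an aromatic carbon, and it amounts to a 1.5-fold higher number from compound 2 to compound 3 (0.18 log units; within the scatter). A change of a different group in a different compound pair can only serve as a rough guide. For the measured compounds named here, still, with nothing measured so far standing outside the scatter, no step beyond the scatter is expected in this assay. The expected step is a 1.2-fold lower number from compound 1 to compound 4 (0.07 log units; within the scatter). For compound 4 the estimated value is 0.6 10^-6 cm/s, with an expected range from 0.3 10^-6 cm/s to 1.2 10^-6 cm/s.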

Compound 4, apparent permeability: 1.1 10^-6 cm/s
Estimate against measurement, compound 4: 1.8-fold (0.26 log units) below; low and high end bracket the measured number.
By their numbers in this assay, from the lowest: compounds 2, 3, 1 and 4 (each within the scatter of the next, the first and the last beyond it).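

Among these compounds, on an amide-type nitrogen, 5-carboxypyrazin-2-yl in place of 6-carboxypyridin-2-yl gives in this assay a 1.6-fold higher number from compound 1 to compound 4 (0.20 log units; within the scatter), the first direct reading of a change at this place. The step stays within the scatter, so this single pair shows that the ring on the amide-type nitrogen can go from one hetero atom to two, with a carboxy group kept on it, without a readable shift in the number. It speaks for this one exchange on the shared core and for no other ring at this place. No measurement shown here gives a reason for this result, and none ties the outcome to a property of either group.

Every compound shown carries either a carboxylic acid or a 1H-tetrazol-5-yl group, so it remains open how the number would respond if a methyl ester or a primary amide stood in that role on the same core. From the compounds shown here alone, it also remains open whether a ring with no acid group at all, for example one carrying a methoxy group, would step beyond the scatter from compound 1 or from compound 4.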